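Arylhydrazone series: the anilide ring swap toward compound 3

This account rests on a few compounds, and the source may have more. Where it says the series, first, only, none or still open, it means among the compounds named here.

Measured so far:
compound 1 `CC1CC/C(=N\Nc2cccc(I)c2)c2ncc(C(=O)O)c(=O)n21` — 1000 umol/kg
compound 2 `CC1CC/C(=N\Nc2cccc(C(=O)O)c2)c2ncc(C(=O)O)c(=O)n21` — > 100 umol/kg

Within the data shown here, compound 1 is the only member with a number in a functional assay on the whole organism for inhibition, with Rattus norvegicus as the target; a higher number here means that more compound is needed for the effect, a lower number that less compound is needed; in this assay compound 1 gives 1000 umol/kg. For compound 2, this assay reports only a limit, > 100 umol/kg, which is not a number. Among the measured compounds shown here, the single step, a step that the limit leaves unreadable from compound 1 to compound 2, therefore gives no readable size; see (the limit of > 100 umol/kg in this assay, at which 1 of the 2 values shown sits).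

Compound 3 `CCc1ccc(N/N=C2\CCC(C)n3c2ncc(C(=O)O)c3=O)cc1` is not yet measured. It differs from compound 1 as follows: 4-ethylphenyl in place of 3-iodophenyl on an amine nitrogen. No measured step touches this change, so nothing shown supports a shift in either direction beyond the scatter, and the working expectation is a step of no change at the digits printed from compound 1 to compound 3 (within the scatter), meaning no change beyond the scatter. Compound 3 is estimated at 1000 umol/kg, with a range from 300 umol/kg to 3000 umol/kg.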

Compound 3, dose for 50% inhibition: > 1000 umol/kg
Compound 3: no number, only a limit; the forecaster's own chance of this, stated with the estimate: 40%; the middle value lies on the limit itself.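

In this assay, 4-ethylphenyl in place of 3-iodophenyl on an amine nitrogen gives a number no lower from compound 1 to compound 3 (the limit leaves the size open). Among these compounds, this is the first step with a readable direction: this change brings no lower number, whereas the earlier step to the carboxy compound could not be read even for direction. Its size stays unreadable because compound 3 has only a limit and no number: the limit of > 1000 umol/kg in this assay, at which 1 of the 3 values shown sits.

Since 3-iodophenyl and 4-ethylphenyl differ in both the group and its place on the ring, the compounds shown do not separate these two effects. They also leave open whether an amine on the aromatic ring, or a chain longer than ethyl, would bring the number in this assay below that of compound 1.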